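The compounds below may be only part of what the source reports. "The series", "measured", "known", "first", "only" and "open" are said of these compounds alone.

Series so far, in an ADME assay on J774.A1 cells (Mus musculus) for cytotoxicity, read by MTT assay, with a stated time of 48 h; a higher number here means that more compound is tolerated, a lower number that less compound is tolerated
compound 1 `C/C(=C\c1ccccc1)C(=O)/C=C/c1ccc(N(C)C)cc1` gives 20200 nM
compound 2 `COc1ccc(/C=C/C(=O)/C(C)=C/c2ccc(OC)cc2)cc1` gives 34100 nM
compound 3 `COc1ccc(/C=C(\C)C(=O)/C=C/c2ccc([N+](=O)[O-])cc2)cc1` gives 30000 nM

Compound 3 does not separate from the other two compounds, as its value lies within the scatter of both compound 1 and compound 2. Compound 4 `COc1ccc(/C=C(\C)C(=O)/C=C/c2ccc(N(C)C)cc2)cc1` keeps the rest of compound 3 and carries dimethylamino in place of nitro on an aromatic carbon, para to a large group (dimethylamino in place of nitro on an aromatic carbon). For the measured compounds named here, no measured step makes this exact exchange. The closest evidence is the exchange of methoxy for nitro, a 1.1-fold lower number from compound 2 to compound 3 (0.06 log units; within the scatter), which is small. Compound 1 also carries dimethylamino and gives 20200 nM, which does not separate it from the nitro-bearing compound 3. Nothing measured therefore points to a large step in this assay, and only a slight drift toward the value of compound 1 is expected. The expected change is a 1.2-fold lower number from compound 3 to compound 4 (0.06 log units; within the scatter), which stays within the scatter. Compound 4 is estimated at 26000 nM, with an expected range from 13000 nM to 50000 nM.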

Compound 4, half-maximal cytotoxic concentration: 36200 nM
Compound 4: middle estimate off by 1.4-fold (0.14 log units), on the low side, within the range that was stated.
By their numbers in this assay, from the lowest: compounds 1, 3, 2 and 4 (each within the scatter of the next).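

In this assay, the direct exchange on an aromatic carbon para to a large group gives a 1.2-fold higher number from compound 3 to compound 4 (0.08 log units; within the scatter) and does not tell dimethylamino from nitro. Dimethylamino in place of methoxy at the same place gives a 1.1-fold higher number from compound 2 to compound 4 (0.03 log units; within the scatter), so the three groups seen here, nitro, methoxy and dimethylamino, do not separate in this read-out. Methoxy in place of hydrogen on an aromatic carbon gives a 1.8-fold higher number from compound 1 to compound 4 (0.25 log units; within the scatter) and also stays within the scatter, so no step among these compounds marks either place as one that moves the number.

As far as these compounds go, whether a carboxylic acid, a primary amine or a longer chain at the para place would step beyond the scatter remains open. No supporting measurement bears on this result.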